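Swapping a fluorinated phenyl amide for a tert-butyl isoxazole

The source may hold more compounds than are shown below. What is called first, only, known or untested is meant among the compounds shown, and "the series" means these compounds.

Compound 1 `Cc1ccc(NC(=O)c2ccc(C)c(C(F)(F)F)c2)cc1OC1CCN(C(=O)c2cccnc2)CC1` carries a 4-methyl-3-(trifluoromethyl)phenyl group on the amide carbonyl carbon. In an ADME assay on BaF3 cells (Mus musculus) for antiproliferative activity (a lower number here means a stronger inhibitor of growth, a higher number a weaker inhibitor of growth), compound 1 gives 5470 nM. Compound 2 `Cc1ccc(NC(=O)c2cc(F)cc(C(F)(F)F)c2)cc1OC1CCN(C(=O)c2cccnc2)CC1` differs only in that aryl ring. In this assay compound 2 reaches only the limit, > 10000 nM. The step of an at least 1.8-fold higher number from compound 1 to compound 2 (0.26 log units; that floor lies within the scatter) is therefore known only as a floor, set by the limit of > 10000 nM in this assay, at which 1 of the 2 values shown sits. Compound 3 `Cc1ccc(NC(=O)c2cc(C(C)(C)C)on2)cc1OC1CCN(C(=O)c2cccnc2)CC1` is the untested member: 5-(tert-butyl)-1,2-oxazol-3-yl in place of 3-fluoro-5-(trifluoromethyl)phenyl on a carbonyl carbon. Going by the values given here, no measured step covers this kind of exchange; the single step known swaps one phenyl pattern for another and is itself bounded by a limit. Compound 2 stands at that limit, so the starting point is uncertain. Compound 3 is expected to return into the measurable range, with an at least 1.6-fold lower number from compound 2 to compound 3 (0.22 log units; that floor lies within the scatter) read against a floor rather than a number. For compound 3 the estimate is 6000 nM, expected to lie between 1500 nM and 20000 nM.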

Compound 3, concentration for 50% growth inhibition: > 10000 nM
Compound 3: only a limit was reported (the forecaster's own chance of this, stated with the estimate: 35%); middle value at least 1.6-fold (0.22 log units) from the limit.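

Compound 3 gives only a limit in this assay, > 10000 nM, so the one ring at this place that is not a phenyl does not yield a measured number. Against the one measured value, the change gives an at least 1.8-fold higher number from compound 1 to compound 3 (0.26 log units; that floor lies within the scatter), so no real loss of activity is established. The step from compound 2 to compound 3 cannot be read, as both compounds rest on the same limit: the limit of > 10000 nM in this assay, at which 2 of the 3 values shown sit.

On these data alone, it remains open how far the true values of compound 2 and compound 3 lie past that limit, and whether either differs from compound 1 at all. Also open, as far as these compounds go, is whether an amine or a carboxylic acid in place of the tert-butyl on the 1,2-oxazol-3-yl ring would give a measurable number in this assay.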